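This account rests on a few compounds, and the source may have more. Where it says the series, first, only, none or still open, it means among the compounds named here.

The three measured compounds and their largest responses in a functional assay on HEK293 cells for agonist activity at Bile acid receptor (Homo sapiens); a higher number here means a larger maximal response, a lower number a smaller maximal response:
compound 1, `CN(Cc1cccc(C(=O)O)c1)c1ccc(OCc2c(-c3c(Cl)cccc3Cl)noc2C2CC2)nc1C(F)(F)F`: 79%
compound 2, `O=C(O)c1cccc(OCc2ccc(OCc3c(-c4c(Cl)cccc4Cl)noc3C3CC3)nc2C(F)(F)F)c1`: 62%
compound 3, `CC(Oc1cccc(C(=O)O)c1)c1ccc(OCc2c(-c3c(Cl)cccc3Cl)noc2C2CC2)nc1C(F)(F)F`: 50%

Compound 3 stands lowest of the three. The nearest is compound 2, where the step reads a number 12 percentage points lower from compound 2 to compound 3 (beyond the scatter); the furthest is compound 1, where the step reads a number 29 percentage points lower from compound 1 to compound 3 (beyond the scatter). The remaining step, a number 17 percentage points lower from compound 1 to compound 2 (beyond the scatter), completes the set.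

Compound 4, `CC(Oc1ccc(C(=O)O)cc1)c1ccc(OCc2c(-c3c(Cl)cccc3Cl)noc2C2CC2)nc1C(F)(F)F`, has the same atoms as compound 3, joined differently: 4-carboxyphenyl in place of 3-carboxyphenyl on an oxygen on a saturated carbon. None of the three measured steps touches this part of the molecule. Each of them alters the link between the shared core and the carboxyphenyl ring, while the carboxyl itself keeps its place on that ring. Among the compounds with values here, there is therefore no measured step that bears directly on the move from compound 3 to compound 4. With no guide, the step expected is no change at the digits printed from compound 3 to compound 4 (within the scatter), none beyond the scatter, though the direction is open. Compound 4 is thus estimated at 50% in this assay, within 30% to 70%.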

Compound 4, largest response reached (reported as efficacy), in percent of the reference or control that the assay uses: 70%
The estimate for compound 4 lay 20 percentage points below the measured number; the range from low to high includes it.
By their numbers in this assay, from the lowest: compound 3; then compounds 2, 4 and 1 (each within the scatter of the next, the first and the last beyond it).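

In this assay, the 4-carboxyphenyl group on the oxygen in place of 3-carboxyphenyl gives a clear step (a number 20 percentage points higher from compound 3 to compound 4 (beyond the scatter)), the first sign that the place of the carboxyl on this ring, and not only the link to the shared core, bears on the maximal response. With the carboxyl so placed, the 1-(4-carboxyphenoxy)ethyl group can no longer be told apart from the other two links (a number 8 percentage points higher from compound 2 to compound 4 (within the scatter); a number 9 percentage points lower from compound 1 to compound 4 (within the scatter)), so the deficit of compound 3 does not hold for the 1-(4-carboxyphenoxy)ethyl group. Nothing measured here explains this step.

Going by these compounds, whether the same shift of the carboxyl would pay with the (3-carboxybenzyl)(methyl)amino or (3-carboxyphenoxy)methyl links stays open. So does how an amide or a tetrazole in place of the carboxylic acid would read in this assay.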